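The compounds below may be only part of what the source reports. "The series", "measured", "known", "first", "only" and "open" are said of these compounds alone.

Measured compounds:
- compound 1 `COc1cnc(N2CCC(CCCNc3ccc4c(c3)OCC4=O)CC2)nc1` – in a functional assay on CHO-K1 cells for agonist activity at Glucose-dependent insulinotropic receptor (Mus musculus), read by HTRF and cAMP accumulation, with a stated time of 30 min (a lower number here means that less compound is needed, a higher number that more compound is needed for the effect), compound 1 gives 60 nM
- compound 2 `CC(C)c1noc(N2CCC(CCCNc3ccc4c(c3)OCC4=O)CC2)n1` – in this assay compound 2 gives "not determined" (no result reported)

Compound 1 and compound 2 share the same core and differ only in the ring attached to the amine nitrogen in the six-membered ring. Among the compounds with values here, for compound 2 no measurement was reported in this assay, so it stands without a number; the only value available in this set is that of compound 1.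

Compound 3 `CC(C)c1nsc(N2CCC(CCCNc3ccc4c(c3)OCC4=O)CC2)n1` follows from compound 2 by one change: 3-isopropyl-1,2,4-thiadiazol-5-yl in place of 3-isopropyl-1,2,4-oxadiazol-5-yl on an amine nitrogen in a ring. Sulfur replaces oxygen in an otherwise unchanged five-membered ring, with the isopropyl group kept in place. Within the data shown here, since compound 2 has no value, no step can be computed, and the expectation must rest on compound 1 alone, with a wide range. Compound 3 is estimated at 80 nM in this assay, expected to lie between 20 nM and 400 nM.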

Compound 3, half-maximal effective concentration: 812 nM
Estimate against measurement, compound 3: 10-fold (1.01 log units) below; measured number above the stated range.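

In this assay, putting 3-isopropyl-1,2,4-thiadiazol-5-yl in place of 5-methoxypyrimidin-2-yl on the amine nitrogen gives a 14-fold higher number from compound 1 to compound 3 (1.13 log units; beyond the scatter), so the potency of this series clearly depends on the group at this position. Compound 2 has no number, so the step from it to compound 3, the exchange of oxygen for sulfur, cannot be read. Nothing available explains the size of the measured step.

This exchange alters both the ring and its substituent, so the compounds shown do not separate the effect of one from the other. A 5-isopropylpyrimidin-2-yl or a 3-methoxy-1,2,4-thiadiazol-5-yl group on the same nitrogen would change only one of the two.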